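The source may report more compounds than this note shows. Statements on the series, on what has been measured and on what is new or still open speak of the compounds shown alone.

Among the compounds with values here, in a functional assay on HO8910 cells (Homo sapiens) for inhibition, read by MTT assay, with a stated time of 24 h, tested at 100 ug/mL (on this read-out lower numbers stand for less inhibition of growth and higher numbers for more inhibition of growth at the one concentration tested), only two compounds have numbers so far. Compound 1 `O=C(CCCCC1CCSS1)Nc1ccc(OC(F)(F)F)cc1` gives 84.5%, while compound 2 `O=C(CCCCC(S)CCS)Nc1ccc(F)cc1` gives 22.3%, the lower of the two, and the gap between them lies beyond the scatter. These two compounds differ in more than one place, so their gap cannot be pinned on any single change. Compound 3 `O=C(CCCCC(S)CCS)Nc1ccc(OC(F)(F)F)cc1` matches compound 2 except for one swap: trifluoromethoxy in place of fluoro on an aromatic carbon. Within the data shown here, no measured pair shows this swap alone, which leaves its size in this assay uncertain. Among the measured compounds shown here, the new group is the one carried by compound 1 at 84.5%, so a rise is a reasonable expectation. The expected change is an increase beyond the scatter, a number 29.7 percentage points higher from compound 2 to compound 3 (beyond the scatter). Compound 3 is estimated at 52%, with an expected range of 28% to 80%.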

Compound 3, percent growth inhibition at one concentration: 66.8%
Compound 3: the middle estimate sits 14.8 percentage points below what was measured; measured number inside the range.
By their numbers in this assay, from the lowest: compound 2; then compound 3; then compound 1.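

In this assay, within the data shown here, trifluoromethoxy in place of fluoro on an aromatic carbon, para to a large group, gives a number 44.5 percentage points higher from compound 2 to compound 3 (beyond the scatter), so this single swap on the open-chain compounds brings a large rise that no earlier pair could isolate. The ring also counts: replacing the five-membered non-aromatic ring with 2 hetero atoms by the open chain of the same heavy-atom count, on a saturated chain carbon, gives a number 17.7 percentage points lower from compound 1 to compound 3 (beyond the scatter), a modest fall that is still beyond the scatter. Nothing available explains why either change moves growth inhibition as it does.

From the compounds shown here alone, whether the trifluoromethoxy swap would give a step of similar size on the ring-bearing compounds remains open. So does the outcome with other groups at the same aromatic carbon, such as chloro, methoxy or an amine, or with a longer chain leading to the carbonyl.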